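A few compounds are considered here, and "the series" means these few. Any claim that something is new, unique, unknown or untested is made for them only; others in the source may bear on it.

Of the compounds shown here, three have been measured. Compound 1 `O=C1C(=O)N(CN2CCN(c3ccnc4cc(Cl)ccc34)CC2)c2cccc(Br)c21` gives 15100 nM in a functional assay on MCF7 cells (Homo sapiens) for cytotoxicity, read by sulforhodamine B assay, with a stated time of 48 h; on this read-out higher numbers stand for weaker inhibition of growth and lower numbers for stronger inhibition of growth. Compound 2 `O=C1C(=O)N(CN2CCN(c3ccnc4cc(C(F)(F)F)ccc34)CC2)c2cccc(Br)c21` gives 66800 nM in this assay. Compound 3 `NC(=S)N/N=C1/C(=O)N(CN2CCN(c3ccnc4cc(Cl)ccc34)CC2)c2cc(Cl)ccc21` gives 22500 nM in this assay.

Compound 1 and compound 2 share a core and differ in one place: trifluoromethyl in place of chloro on an aromatic carbon. On this change the number moves as a 4.4-fold higher number from compound 1 to compound 2 (0.65 log units; beyond the scatter). Compound 3 is built on a different core; how its core differs from that of compound 1 is not broken down here. The values of compound 3 and compound 1 lie within the scatter of each other, while the value of compound 3 stands below that of compound 2.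

Compound 4 `NC(=S)N/N=C1/C(=O)N(CN2CCN(c3ccnc4cc(C(F)(F)F)ccc34)CC2)c2cc(Cl)ccc21` has not yet been measured in this assay. It stands to compound 3 as compound 2 stands to compound 1: trifluoromethyl in place of chloro on an aromatic carbon. The place of the change is described in the same words for both pairs, so this is the same change made on a second core. Within the data shown here, the only measured instance of it is the step from compound 1 to compound 2, which gave a higher number. If the second core responds in the same direction, compound 4 is expected to show a step of a 3.8-fold higher number from compound 3 to compound 4 (0.58 log units; beyond the scatter), resting on the single measured step of a 4.4-fold higher number from compound 1 to compound 2 (0.65 log units; beyond the scatter). Among the measured compounds shown here, because a 4.4-fold higher number from compound 1 to compound 2 (0.65 log units; beyond the scatter) is the only guide, and the two cores are not the same, the range around the estimate is kept wide. Compound 4 is estimated at 85000 nM, with a plausible span from 30000 nM to 250000 nM.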

Compound 4, concentration for 50% growth inhibition: 24600 nM
The estimate for compound 4 lay 3.5-fold (0.54 log units) above the measured number; the whole stated range lies above it.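

On the second core, trifluoromethyl in place of chloro on an aromatic carbon gives a 1.1-fold higher number from compound 3 to compound 4 (0.04 log units; within the scatter), so compound 3 and compound 4 cannot be told apart in this assay. The clear step seen on the first core therefore does not carry over to the second, and the size of this step in this assay differs between the two cores: the same change on two cores in this assay, a 4.4-fold higher number (0.65 log units; beyond the scatter) from compound 1 to compound 2 and a 1.1-fold higher number (0.04 log units; within the scatter) from compound 3 to compound 4, 4.0-fold (0.61 log units) apart, beyond the scatter of two such steps

Among these compounds, this does not show which feature of the cores accounts for the difference, since they are not separated by a single change, and with only one pair on each core it gives no rule for what the same change would do on a third core.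

The compounds shown carry only chloro or trifluoromethyl at this aromatic carbon, so it remains open how a methoxy group, a nitrile or an amine in the same place would behave on either core. From the compounds shown here alone, it also remains open which of the two steps is the more typical for this series, as each rests on a single pair of compounds.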